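Replacing the carbamate cap with a thiophene amide

A few compounds are considered here, and "the series" means these few. Any claim that something is new, unique, unknown or untested is made for them only; others in the source may bear on it.

In an ADME assay on HepG2 2.2.15 cells (Homo sapiens) for cytotoxicity (a lower number here means that less compound is tolerated, a higher number that more compound is tolerated), compound 3 `CC(C)(C)OC(=O)Nc1ncc(C(Oc2ccc3cc(Br)ccc3c2)c2ccc(Cl)cc2)s1` gives > 50000 nM, which is a limit of the assay rather than a number. Compound 1 `Cc1cc(C(C)C)ccc1OC(c1ccc(Cl)cc1)c1cnc(NC(=O)OC(C)(C)C)s1` also reaches only a limit, > 50000 nM. Compound 2 `Cc1cc(Br)cc(OC(c2ccc(Cl)cc2)c2cnc(NC(=O)OC(C)(C)C)s2)c1` likewise stops at a limit, > 50000 nM. Because all three values sit at the limit of > 50000 nM in this assay, at which 3 of the 3 values shown sit, the steps a step that the two limits leave unreadable from compound 1 to compound 2, a step that the two limits leave unreadable from compound 1 to compound 3 and a step that the two limits leave unreadable from compound 2 to compound 3 cannot be read. Compound 4 `O=C(Nc1ncc(C(Oc2ccc3cc(Br)ccc3c2)c2ccc(Cl)cc2)s1)c1cccs1` differs from compound 3 by thiophen-2-yl in place of tert-butoxy on a carbonyl carbon. Among the measured compounds shown here, none of the measured steps touches this part of the molecule, so they give no guide; every compound so far is simply tolerated up to the limit. For compound 4 the expected step is a number no higher from compound 3 to compound 4 (the limit leaves the size open), that is, nothing beyond the scatter. Compound 4 is therefore estimated at 50000 nM, within 20000 nM to 120000 nM.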

Compound 4, half-maximal cytotoxic concentration: "not toxic" (no number reported)
Compound 4: no number reported, so the estimate cannot be set against anything.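

Among the compounds shown here, compound 4 is reported only as not toxic, with no number, so no step from compound 3 to compound 4 can be read. In this assay, the compounds shown leave open whether thiophen-2-yl in place of tert-butoxy changes the tolerated concentration at all.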